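Adding One Chain Carbon to Compound 3

A few compounds are considered here, and "the series" means these few. Any claim that something is new, unique, unknown or untested is made for them only; others in the source may bear on it.

In a physicochemical assay for solubility, at pH 7.4 (on this read-out lower numbers stand for lower solubility and higher numbers for higher solubility), compound 1 (`NS(=O)(=O)c1ccc(S(=O)(=O)CCCO)cc1`) gives 7200 ug/mL and compound 2 (`NS(=O)(=O)c1ccc(SCCO)c(F)c1`) gives 6000 ug/mL while compound 3 (`NS(=O)(=O)c1ccc(S(=O)(=O)CCCO)s1`) reaches 14600 ug/mL as the highest of the three. Its gaps to both of the others lie beyond the usual scatter of repeated measurements, though only narrowly.

The next compound is compound 4 (`NS(=O)(=O)c1ccc(S(=O)(=O)CCCCO)s1`), which differs from compound 3 in one place (hydroxymethyl in place of hydroxy on a saturated chain carbon, three bonds along the chain from a sulfonyl sulfur). It carries hydroxymethyl in place of hydroxy on a saturated chain carbon, three bonds along the chain from a sulfonyl sulfur, so 3-hydroxypropyl becomes 4-hydroxybutyl.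

Among the compounds with values here, no two measured compounds differ in just one place, so the data offer no direct guide to this step, and any forecast is uncertain. The expected move in this assay is small and downward, with a 1.5-fold lower number from compound 3 to compound 4 (0.19 log units; within the scatter) as the estimate and no expected exit from the scatter. For compound 4 the estimated value is 9500 ug/mL with an expected range from 4500 ug/mL to 17000 ug/mL on this measure.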

Compound 4, solubility: 9900 ug/mL
Estimate against measurement, compound 4: 1.0-fold (0.02 log units) below, within the range that was stated.
By their numbers in this assay, from the lowest: compounds 2, 1, 4 and 3 (each within the scatter of the next, the first and the last beyond it).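

In this assay, within the data shown here, compound 3 and compound 4 form the first pair in this set that differs in one place only, so a change on the saturated chain, three bonds along the chain from a sulfonyl sulfur, can now be read directly. Going from 3-hydroxypropyl to 4-hydroxybutyl gives a 1.5-fold lower number from compound 3 to compound 4 (0.17 log units; within the scatter), so this read-out does not separate the two chains. No measurement at hand explains the size of this step.

On these data alone, it remains open whether a longer chain, or an amine or a carboxylic acid in place of the hydroxy, would also stay within the scatter of compound 3. A single step also cannot show whether the same added carbon would read alike on the core of compound 1.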